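Adding a second chlorine to the core of compound 1

The source may hold more compounds than are shown below. What is called first, only, known or untested is meant among the compounds shown, and "the series" means these compounds.

Measured compounds:
Compound 1 `ClCc1cccc(Cn2cnc3c(Cl)ncnc32)c1` — in a functional assay on SNB-75 cells (Homo sapiens) for cytotoxicity, read by sulforhodamine B assay, with a stated time of 48 h (a higher number here means a weaker inhibitor of growth, a lower number a stronger inhibitor of growth), compound 1 gives 2080 nM.
Compound 2 `ClCc1ccc(Cn2cnc3nc(Cl)nc(Cl)c32)cc1` — in this assay compound 2 gives 2080 nM.

Compound 1 stands level with compound 2 in this assay at the digits shown, and the two values lie within the scatter of each other; no ordering between them can be read from these numbers.

Compound 3 `ClCc1cccc(Cn2cnc3c(Cl)nc(Cl)nc32)c1` is not yet measured. It differs from compound 1 by chloro in place of hydrogen on an aromatic carbon, sitting between two ring nitrogen atoms of the shared core. Within the data shown here, no measured pair shows this exact change, so its effect here is unknown. With compound 2 sitting at the same level as compound 1 despite carrying two chlorines on its core, the expected step of a 1.0-fold lower number from compound 1 to compound 3 (0.02 log units; within the scatter) is none beyond the scatter. Compound 3 is therefore estimated at 2000 nM, with a likely range from 700 nM to 6000 nM.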

Compound 3, concentration for 50% growth inhibition: 2040 nM
For compound 3 the middle estimate is 1.0-fold (0.01 log units) below the measured one; the range from low to high includes it.
By their numbers in this assay, from the lowest: compounds 3, 1 and 2 (each within the scatter of the next).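

Among these compounds, putting a chloro group on this aromatic carbon, between two ring nitrogen atoms of the shared core, can now be judged directly for the first time. In this assay this single replacement of hydrogen gives a 1.0-fold lower number from compound 1 to compound 3 (0.01 log units; within the scatter), so compound 1 and compound 3 cannot be told apart by this read-out, and the position accepts a chloro group with no detectable effect on the reading. Nothing available explains this result.

Going by these compounds, whether this position tolerates other groups remains open, since one chloro group says nothing about how an amine, a methoxy group or a longer chain would read here. It is also unknown whether the chloromethyl group contributes to the growth inhibition, a question that a plain methyl group in its place could address.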